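Cinnamamide aryl swap: aminophenyl replaces difluorophenyl

A few compounds are considered here, and "the series" means these few. Any claim that something is new, unique, unknown or untested is made for them only; others in the source may bear on it.

The series shares the core of compound 1 `COc1ccc(C(=O)c2cc(OC)c(OC)c(OC)c2)cc1NC(=O)/C=C/c1cc(OC)c(OC)c(OC)c1`. In a functional assay on HT-29 cells (Homo sapiens) for cytotoxicity, read by MTT assay, with a stated time of 72 h (on this read-out lower numbers stand for stronger inhibition and higher numbers for weaker inhibition), compound 1 gives 3100 nM. Among the compounds with values here, compound 2 `COc1ccc(C(=O)c2cc(OC)c(OC)c(OC)c2)cc1NC(=O)/C=C/c1ccc(F)c(F)c1` gives 4200 nM, the highest of the two numbers so far, and the step of a 1.4-fold higher number from compound 1 to compound 2 (0.13 log units; within the scatter) stays within the scatter. Compound 3 `COc1ccc(C(=O)c2cc(OC)c(OC)c(OC)c2)cc1NC(=O)/C=C/c1ccc(N)cc1` is not yet measured. It differs from compound 2 by 4-aminophenyl in place of 3,4-difluorophenyl on a double-bonded chain carbon bound to a double-bonded chain carbon. Within the data shown here, the only measured step that bears on this site is a 1.4-fold higher number from compound 1 to compound 2 (0.13 log units; within the scatter), where an aryl swap on the same chain carbon left the number within the scatter. Among the measured compounds shown here, no measured step brings a hydrogen-bond donor or acceptor into this ring, so the direction of any change is open. The expectation for compound 3 in this assay is a step of a 1.2-fold lower number from compound 2 to compound 3 (0.08 log units; within the scatter), not beyond the scatter. Compound 3 is therefore estimated at 3500 nM, with a range from 1500 nM to 8000 nM.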

Compound 3, half-maximal inhibitory concentration: 5600 nM
Beside the measured number, compound 3's estimate is 1.6-fold (0.20 log units) below it, and the stated range covers the measured number.
By their numbers in this assay, from the lowest: compounds 1, 2 and 3 (each within the scatter of the next).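

In this assay, within the data shown here, 4-aminophenyl, the first group at this place to carry a hydrogen-bond donor, gives a 1.3-fold higher number from compound 2 to compound 3 (0.12 log units; within the scatter) and, set against 3,4,5-trimethoxyphenyl, gives a 1.8-fold higher number from compound 1 to compound 3 (0.26 log units; within the scatter) as well. With the earlier step, all three aryl groups on the double-bonded chain carbon now lie within the scatter of one another, so a single pair no longer carries the reading: a third, differently substituted ring gives no step beyond the scatter. Nothing available explains why these swaps leave the number within the scatter.

As far as these compounds go, whether a carboxylic acid or a dimethylamino group on this ring would give a step beyond the scatter remains open. So does whether a saturated ring or a longer chain in place of the aryl group would do so, and the three compounds shown cannot settle either question.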